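Chloro to Methylsulfonyl on a Fatty-Acid Amide Hydrolase Inhibitor

The source may report more compounds than this note shows. Statements on the series, on what has been measured and on what is new or still open speak of the compounds shown alone.

Measured compounds:
compound 1, `O=C(CCCCCCc1ccccc1C(=O)O)c1ncc(-c2ccccn2)o1`, > 600 nM
compound 2, `O=C(CCCCCCc1ccccc1Cl)c1ncc(-c2ccccn2)o1`, 1.9 nM

Among the measured compounds shown here, in an assay for inhibition of Fatty-acid amide hydrolase 1 (Rattus norvegicus) (on this read-out lower numbers stand for stronger inhibition and higher numbers for weaker inhibition), compound 2 gives 1.9 nM, which is the only number reported in this set. Compound 1 gives > 600 nM, and this is a limit of the assay, not a number (the limit of > 600 nM in this assay, at which 1 of the 2 values shown sits). For the measured compounds named here, the single measured step is an at least 310-fold lower number from compound 1 to compound 2 (2.49 log units; beyond the scatter).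

Compound 3, `CS(=O)(=O)c1ccccc1CCCCCCC(=O)c1ncc(-c2ccccn2)o1`, differs from compound 2 by methylsulfonyl in place of chloro on an aromatic carbon. Going by the values given here, the only measured step at this position is an at least 310-fold lower number from compound 1 to compound 2 (2.49 log units; beyond the scatter), which shows that exchanging the chloro for a carboxy group moved the value up to the limit. Methylsulfonyl is neither of these two groups, and no measured pair shows its effect, so the expectation rests on analogy: a move in the same direction as the carboxy, but of uncertain size. The expected step is therefore a 42-fold higher number from compound 2 to compound 3 (1.62 log units; beyond the scatter), a loss beyond the scatter. In this assay compound 3 is estimated at 80 nM, with a range from 10 nM to 600 nM.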

Compound 3, inhibition constant: 37 nM
Estimate against measurement, compound 3: 2.2-fold (0.33 log units) above, within the range that was stated.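

The change from chloro to methylsulfonyl gives a 19-fold higher number from compound 2 to compound 3 (1.29 log units; beyond the scatter), so a loss at this position is not confined to the carboxy of compound 1. Methylsulfonyl also stands apart from carboxy, with an at least 16-fold lower number from compound 1 to compound 3 (1.20 log units; beyond the scatter), which places the three groups in an order in this assay, with methylsulfonyl in the middle and chloro giving the strongest inhibition. The value of compound 1 is a limit of the assay and not a number, so this second step has a lower bound but no known full size: the limit of > 600 nM in this assay, at which 1 of the 3 values shown sits.

The compounds shown leave open whether any other group on this aromatic carbon, such as fluoro, methyl or methoxy, can match chloro, and whether an amine would fall closer to methylsulfonyl or to carboxy. They also do not tell what separates the three groups, or whether the same order would hold on a shorter or longer chain.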